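The source may report more compounds than this note shows. Statements on the series, on what has been measured and on what is new or still open speak of the compounds shown alone.

Compound 3, `COc1cc(N)c(Cl)cc1NC(=O)C1CCN(C2CCCC2)CC1`, carries a cyclopentyl on an amine nitrogen in a ring. In a functional assay on the whole organism for antagonist activity, with Mus musculus as the target (a lower number here means that less compound is needed, a higher number that more compound is needed for the effect), compound 3 gives no number but only a limit, > 10 mg/kg. Among the measured compounds shown here, the two other compounds measured so far likewise stop at limits. Compound 1, `CCCCN1CCC(C(=O)Nc2cc(Cl)c(N)cc2OC)CC1`, gives in this assay the limit > 10 mg/kg. Compound 2, `COc1cc(N)c(Cl)cc1NC(=O)C1CCN(Cc2ccccc2Cl)CC1`, gives in this assay the limit > 4 mg/kg. For the measured compounds named here, with every value a limit, no step between these compounds can be read: a step that the two limits leave unreadable from compound 1 to compound 3, a step that the two limits leave unreadable from compound 2 to compound 3 and a step that the two limits leave unreadable from compound 1 to compound 2 all stay without a size. Compound 3 thus stands nowhere definite on the numbers shown; it shares (the limit of > 10 mg/kg in this assay, at which 2 of the 3 values shown sit), and the limit of > 4 mg/kg in this assay, at which 1 of the 3 values shown sits, is the only other mark in the set.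

Compound 4, `CCC(CC)CN1CCC(C(=O)Nc2cc(Cl)c(N)cc2OC)CC1`, differs from compound 3 in one place: 2-ethylbutyl in place of cyclopentyl on an amine nitrogen in a ring. Going by the values given here, neither the step with cyclopentyl in place of butyl nor the one with cyclopentyl in place of 2-chlorobenzyl gives a readable size, so no measured step supports a direction for this change. The step from compound 3 to compound 4 is therefore expected to be a step that the limit leaves unreadable from compound 3 to compound 4, that is, no change beyond the scatter. Compound 4 is estimated at 15 mg/kg, within a range from 5 mg/kg to 50 mg/kg, with a good chance that this assay again reports only a limit.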

Compound 4, dose for half-maximal effect: > 10 mg/kg
Compound 4 ended at the assay's limit; the forecaster's own chance of this, stated with the estimate: 70%; the middle value does not contradict the limit.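

In this assay compound 4 also gives only a limit, > 10 mg/kg. None of the steps from compound 1, compound 2 or compound 3 to compound 4 can be read. The compounds shown leave open what dose of any of them gives the half-maximal effect, and whether the group on the amine nitrogen in a ring changes that dose at all.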